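The source may hold more compounds than are shown below. What is called first, only, known or untested is meant among the compounds shown, and "the series" means these compounds.

The measured compounds and their values in a functional assay on A549 cells (Homo sapiens) for cytotoxicity, read by MTT assay, with a stated time of 48 h; a higher number here means a weaker inhibitor, a lower number a stronger inhibitor:

compound 1, `C=C[C@@]1(C)O[C@H]1C[C@H]1C(=C)CC[C@@H]2[C@]1(C)CCC[C@]2(C)C(=O)O`: > 40000 nM
compound 2, `C=CC(=C)CC[C@@H]1[C@@]2(C)CCC[C@](C)(COC(=O)/C=C/c3ccc(O)cc3)[C@@H]2CC[C@@]1(C)O`: 20400 nM
compound 3, `C=CC(=C)CC[C@@H]1[C@@]2(C)CCC[C@](C)(COC(=O)/C=C/c3ccc(O)c(OC)c3)[C@@H]2CC[C@@]1(C)O`: 16800 nM

Compound 1 stands apart from the other two on these numbers. Its entry in this assay is a limit of the assay and not a number: compound 1 gives > 40000 nM, which is the limit of > 40000 nM in this assay, at which 1 of the 3 values shown sits. Among the compounds with values here, compound 2 and compound 3 give numbers, and the one measured step between them, a 1.2-fold lower number from compound 2 to compound 3 (0.08 log units; within the scatter), is a methoxy in place of hydrogen on an aromatic carbon; it lies within the scatter.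

Compound 4, `C=C[C@]1(C)O[C@H]1C[C@H]1C(=C)CC[C@@H]2[C@]1(C)CCC[C@]2(C)C(=O)O`, has not been measured. Set against compound 1, (the two compounds have the same atoms and bonds and differ only in configuration as drawn: 1 of 6 stereo elements differ; a stereocentre at a saturated ring carbon is drawn R in compound 1 and S in compound 4). No measured step concerns a change of configuration at a saturated ring carbon, so the step from compound 2 to compound 3 does not bear on this change, and nothing in the shown measurements anchors a step size for it. With compound 1 already at the limit, compound 4 is expected to show no step beyond the scatter, and the step that the limit leaves unreadable from compound 1 to compound 4 is the expectation that follows. Compound 4 is therefore estimated at 60000 nM, with a range from 25000 nM to 150000 nM, most likely reported again only as a limit.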

Compound 4, half-maximal inhibitory concentration: > 40000 nM
Compound 4: no number, only a limit; the forecaster's own chance of this, stated with the estimate: 75%; the middle value does not contradict the limit.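

Compound 4, like compound 1, gives only a limit of the assay and not a number in this assay, so no step can be read between compound 1 and compound 4: the limit of > 40000 nM in this assay, at which 2 of the 4 values shown sit.

The compounds shown leave open whether the change of configuration at the saturated ring carbon alters cytotoxicity at all.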